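The source may hold more compounds than are shown below. What is called first, only, known or untested is meant among the compounds shown, and "the series" means these compounds.

In an ADME assay on MT2 cells (Homo sapiens) for cytotoxicity, read by XTT assay, with a stated time of 4 days (a lower number here means that less compound is tolerated, a higher number that more compound is tolerated), compound 3 `Cc1nc(C(NC(=O)C(=O)Nc2ccc(F)c(Cl)c2)C2CCCCN2)sc1CO` gives > 77800 nM, which is a limit and not a number. Compound 1 `Cc1nc(C(NC(=O)C(=O)Nc2ccc(Cl)cc2)C2CCNCC2)sc1CCO` gives > 78500 nM, which is also a limit. Compound 2 `Cc1nc(C(NC(=O)C(=O)Nc2ccc(Cl)cc2)C2CCCCN2C)sc1CCO` gives a true number, 88000 nM.

Compound 4 `CC(=O)c1ccc(NC(=O)C(=O)NC(c2nc(C)c(CO)s2)C2CCCCN2)cc1` carries 4-acetylphenyl in place of 3-chloro-4-fluorophenyl on an amide-type nitrogen. For the measured compounds named here, the one measured step in this small set is a step that the limit leaves unreadable from compound 1 to compound 2. It has no readable size and does not touch the group that changes here, so no measurement sizes this replacement directly.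

Going by the values given here, with compound 2 at 88000 nM as the only number available, no step beyond the scatter is expected in this assay, and no direction can be favoured. The expected step is a step that the limit leaves unreadable from compound 3 to compound 4. Compound 4 is estimated at 80000 nM, with an expected range from 35000 nM to 150000 nM.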

Compound 4, half-maximal cytotoxic concentration: > 107000 nM
Compound 4: no number, only a limit; the forecaster's own chance of this, stated with the estimate: 65%; middle value at least 1.3-fold (0.12 log units) from the limit.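

Compound 3 and compound 4 both stand only as limits in this assay, so the step between them cannot be read. The compounds shown leave open whether 4-acetylphenyl in place of 3-chloro-4-fluorophenyl on an amide-type nitrogen shifts the half-maximal cytotoxic concentration at all, and in which direction.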